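One Extra Chloro Group, Tested on a Second Core

A few compounds are considered here, and "the series" means these few. Any claim that something is new, unique, unknown or untested is made for them only; others in the source may bear on it.

Measured so far:
Compound 1, `ClCc1ccc(Cn2cnc3c(Cl)ncnc32)cc1`, 1380 nM
Compound 2, `ClCc1cccc(Cn2cnc3ncnc(Cl)c32)c1`, 1770 nM
Compound 3, `ClCc1ccc(Cn2cnc3c(Cl)nc(Cl)nc32)cc1`, 2000 nM

All three were tested in a functional assay on OVCAR-3 cells (Homo sapiens) for cytotoxicity, read by sulforhodamine B assay, with a stated time of 48 h; on this read-out lower numbers stand for stronger inhibition of growth and higher numbers for weaker inhibition of growth. Compound 1 and compound 2 carry the same atoms joined differently; the difference between the two cores is not broken down here, and their values lie within the usual scatter of each other. Compound 3 arises from compound 1 by a single change, (chloro in place of hydrogen on an aromatic carbon), and the step that this made was a 1.4-fold higher number from compound 1 to compound 3 (0.16 log units; within the scatter), so the added chloro group left growth inhibition essentially unchanged.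

Compound 4, `ClCc1cccc(Cn2cnc3nc(Cl)nc(Cl)c32)c1`, is not yet measured. It arises from compound 2 by chloro in place of hydrogen on an aromatic carbon, the same change at a place described in the same words. The step from compound 2 to compound 4 is expected to be a 1.4-fold higher number from compound 2 to compound 4 (0.13 log units; within the scatter) because the matching step was a 1.4-fold higher number from compound 1 to compound 3 (0.16 log units; within the scatter). On that basis compound 4 is estimated at 2400 nM in this assay, with an expected range from 1200 nM to 5000 nM.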

Compound 4, concentration for 50% growth inhibition: 1510 nM
Compound 4: the middle estimate sits 1.6-fold (0.20 log units) above what was measured; the range from low to high includes it.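

In this assay, putting a chloro group in place of hydrogen on the core of compound 2 gave a 1.2-fold lower number from compound 2 to compound 4 (0.07 log units; within the scatter), so growth inhibition stayed within the usual scatter on this core too. Set beside the earlier step, the change shows no measurable difference between the two cores: the same change on two cores in this assay, a 1.4-fold higher number (0.16 log units; within the scatter) from compound 1 to compound 3 and a 1.2-fold lower number (0.07 log units; within the scatter) from compound 2 to compound 4, 1.7-fold (0.23 log units) apart, within the scatter of two such steps. This shows that the chloro group made no clear difference to growth inhibition on either core, but it does not prove that its effect is identical on both, as a small real difference could hide in the scatter, and two pairs of compounds set no rule for other cores.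

Going by these compounds, it remains open whether a different group on the aromatic carbon between two ring nitrogen atoms, such as an amine, a methoxy group or a carboxylic acid, would move growth inhibition on either core. On these data alone, it is also open whether a longer chain there would give a step that rises clear of the scatter.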